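Chain length and cytotoxicity in a tricarboxylate amphiphile series

This account rests on a few compounds, and the source may have more. Where it says the series, first, only, none or still open, it means among the compounds named here.

The compounds share a core bearing three carboxylic acids, capped by a long saturated chain through a carbamate or an amide. Going by the values given here, in an ADME assay on cells (Epithelial cell, Homo sapiens) for cytotoxicity, read by MTT assay (a higher number here means that more compound is needed for the effect, a lower number that less compound is needed), compound 1 `CCCCCCCCCCCCCCCCCCCCCCOC(=O)NC(CCC(=O)O)(CCC(=O)O)CCC(=O)O` gives 360000 nM, the higher of the two numbers so far, though only within the scatter. Compound 3 `CCCCCCCCCCCCCC(=O)NC(CCC(=O)O)(CCC(=O)O)CCC(=O)O` gives 300000 nM in this assay, so the two cannot be told apart. For compound 2 `CCCCCCCCCCCCCCCCCC(=O)NC(CCC(=O)O)(CCC(=O)O)CCC(=O)O` the entry in this assay reads "not determined" (no result reported), so no number is available for it. Compound 4 `CCCCCCCCCCCCCCCCCCOC(=O)NC(CCC(=O)O)(CCC(=O)O)CCC(=O)O` differs from compound 1 by hydrogen in place of butyl on a saturated chain carbon, ten or more bonds along the chain from an oxygen next to a carbonyl group. Since compound 1 at 360000 nM and compound 3 at 300000 nM sit within the scatter, shortening the chain is not expected to matter. The expected step is a 1.1-fold lower number from compound 1 to compound 4 (0.04 log units; within the scatter), none beyond the scatter. Compound 4 is estimated at 330000 nM, in the range 150000 nM to 700000 nM.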

Compound 4, half-maximal effective concentration: 350000 nM
Estimate against measurement, compound 4: 1.1-fold (0.03 log units) below, within the range that was stated.
By their numbers in this assay, from the lowest: compounds 3, 4 and 1 (each within the scatter of the next).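

Within the carbamates, hydrogen in place of butyl on a saturated chain carbon, ten or more bonds along the chain from an oxygen next to a carbonyl group, gives a 1.0-fold lower number from compound 1 to compound 4 (0.01 log units; within the scatter) in this assay as the first comparison of compounds differing in one place. At this position, the butyl therefore makes no difference that this assay can resolve. No measured evidence accounts for this result.

Still open, as far as these compounds go, is whether an amine or a carboxylic acid at this position would shift the number. Also open, from the compounds shown here alone, is how carbamate and amide compare at matched chain length.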